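From Carbamoyl to Nitro on the Shared Core

A few compounds are considered here, and "the series" means these few. Any claim that something is new, unique, unknown or untested is made for them only; others in the source may bear on it.

Measured compounds in a functional assay on SK-OV-3 cells (Homo sapiens) for inhibition, read by MTT assay (on this read-out lower numbers stand for stronger inhibition and higher numbers for weaker inhibition), so far
compound 1 `COc1ccc(/C=C2\c3cc(OC)c(OC)c(OC)c3CC[C@@H]2O)cc1N` gives 740 nM
compound 2 `COc1ccc(/C=C2\c3cc(OC)c(OC)c(OC)c3CC[C@@H]2O)cc1C(N)=O` gives 1440 nM

Compound 2 at 1440 nM lies within the scatter of compound 1 (740 nM), so the two cannot be told apart on these numbers. The next compound to be tested is compound 3 `COc1ccc(/C=C2\c3cc(OC)c(OC)c(OC)c3CC[C@@H]2O)cc1[N+](=O)[O-]` with nitro in place of carbamoyl on an aromatic carbon, ortho to a methoxy group nitro in place of carbamoyl on an aromatic carbon while the rest of the structure stays the same. Among the measured compounds shown here, only one measured step bears on this position, namely a 1.9-fold higher number from compound 1 to compound 2 (0.29 log units; within the scatter) for an exchange at the same aromatic carbon. Neither compound carries nitro, so that step offers only a rough size and no firm direction. The expected change is a 1.3-fold lower number from compound 2 to compound 3 (0.12 log units; within the scatter) and no step beyond the scatter is expected in this assay for this exchange. Compound 3 is therefore estimated at 1100 nM with an expected range from 400 nM to 3000 nM until it is measured.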

Compound 3, half-maximal inhibitory concentration: 4640 nM
Compound 3: middle estimate off by 4.2-fold (0.63 log units), on the low side, and the stated range ends below it.
By their numbers in this assay, from the lowest: compounds 1 and 2 (each within the scatter of the next); then compound 3.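

In this assay this aromatic carbon, ortho to a methoxy group, turns out to respond to the group it carries: nitro in place of carbamoyl gives a 3.2-fold higher number from compound 2 to compound 3 (0.51 log units; beyond the scatter) and nitro in place of amino gives a 6.3-fold higher number from compound 1 to compound 3 (0.80 log units; beyond the scatter) while the earlier pair could not be told apart. Of the three compounds, compound 3 therefore gives the weakest inhibition, with its steps to both others beyond the scatter. No measurement shown accounts for this difference.

The compounds shown leave open whether a nitrile, a carboxylic acid or a hydroxyl group on this carbon would stand with amino and carbamoyl or with nitro. They also leave open whether nitro would give a step of this size at another carbon of the same ring.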